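Chloro to fluoro on the thiourea aryl of compound 3

The source may report more compounds than this note shows. Statements on the series, on what has been measured and on what is new or still open speak of the compounds shown alone.

Compounds measured so far:
compound 1 `O=C(NC(=S)Nc1ccc(F)cc1)c1cn(-c2ccccc2)nc1-c1ccccc1` — 3500 nM
compound 2 `COc1ccc(-c2nn(-c3ccccc3)cc2C(=O)NC(=S)Nc2ccc(F)cc2)cc1` — 1430 nM
compound 3 `O=C(NC(=S)Nc1ccc(Cl)cc1)c1cn(-c2ccccc2)nc1-c1ccc(Cl)cc1` — 3150 nM

In a functional assay on A549 cells (Homo sapiens) for inhibition, read by CCK-8 assay, with a stated time of 48 h (on this read-out higher numbers stand for weaker inhibition and lower numbers for stronger inhibition), compound 3 gives 3150 nM, the second highest of the three numbers. Its nearest neighbour is compound 1, which in this assay gives 3500 nM, a gap that lies within the scatter. Compound 2 is the furthest away, its number in this assay being 1430 nM.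

Compound 4 `O=C(NC(=S)Nc1ccc(F)cc1)c1cn(-c2ccccc2)nc1-c1ccc(Cl)cc1` is not yet measured. It differs from compound 3 by fluoro in place of chloro on an aromatic carbon, that is, (4-chlorophenyl)amino to (4-fluorophenyl)amino. For the measured compounds named here, the only single-point step among the measured compounds, a 2.4-fold lower number from compound 1 to compound 2 (0.39 log units; beyond the scatter), concerns a different position and does not bear on this change. Going by the values given here, no measured pair speaks to a chloro-to-fluoro swap, and compound 1 and compound 3, which carry fluoro and chloro there with another difference elsewhere, sit within the scatter of each other. A step of a 1.1-fold lower number from compound 3 to compound 4 (0.02 log units; within the scatter) is therefore expected, that is, none beyond the scatter. Compound 4 is estimated to give 3000 nM, within 1500 nM to 6000 nM.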

Compound 4, half-maximal inhibitory concentration: 3980 nM
Estimate against measurement, compound 4: 1.3-fold (0.12 log units) below; measured number inside the range.
By their numbers in this assay, from the lowest: compound 2; then compounds 3, 1 and 4 (each within the scatter of the next).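

In this assay, for the compounds shown here, putting (4-fluorophenyl)amino in place of (4-chlorophenyl)amino gives a 1.3-fold higher number from compound 3 to compound 4 (0.10 log units; within the scatter), so this position does not separate the two halogens, which no earlier pair could show. On the other aromatic ring, chloro in place of hydrogen gives a 1.1-fold higher number from compound 1 to compound 4 (0.06 log units; within the scatter), while chloro in place of methoxy gives a 2.8-fold higher number from compound 2 to compound 4 (0.44 log units; beyond the scatter), so among the three groups compared there, only methoxy stands apart. No measurement shown accounts for these readings.

From the compounds shown here alone, whether an amine or a carboxylic acid on that carbon of the thiourea aryl would move the number beyond the scatter remains open. Going by these compounds, it is also open whether a nitrile on the other aromatic ring would match methoxy.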